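The source may report more compounds than this note shows. Statements on the series, on what has been measured and on what is new or still open speak of the compounds shown alone.

Measured compounds:
compound 1, `Cc1ccc(C(=O)CSC(=S)SC(C)(C)C)cc1`: 31600 nM
compound 2, `CCSC(=S)SCC(=O)c1ccccc1C`: 10000 nM
compound 3, `CCSC(=S)SC(C)C(=O)c1ccccc1`: 5010 nM

In a functional assay on HeLa cells (Homo sapiens) for antiproliferative activity, read by resazurin assay (a lower number here means a stronger inhibitor, a higher number a weaker inhibitor), compound 1 gives 31600 nM, the highest of the three numbers. Compound 2 gives 10000 nM in this assay, and compound 3 gives 5010 nM; the gap from compound 1 to compound 2 is the smaller one, the gap from compound 1 to compound 3 the larger, and both lie beyond the usual scatter of repeated measurements. Among the compounds with values here, compounds 2 and 3 differ from compound 1 in more than one place, so no single structural step between them and compound 1 can be separated out.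

Compound 4, `Cc1ccc(C(=O)CSC(=S)SC(C)C)cc1`, differs from compound 1 in one place: hydrogen in place of methyl on a saturated chain carbon bound to two saturated chain carbons and a sulfur. Within the data shown here, no pair of measured compounds shows the effect of this change alone, so the expectation rests on the size of the change, which is small. The step expected from this change, a 1.4-fold lower number from compound 1 to compound 4 (0.16 log units; within the scatter), is estimated to stay within the usual scatter, with a slight lean toward a lower number. Compound 4 is therefore expected to give about 22000 nM in this assay, with a range from 7000 nM to 63000 nM.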

Compound 4, half-maximal inhibitory concentration: 25100 nM
Estimate against measurement, compound 4: 1.1-fold (0.06 log units) below; the range from low to high includes it.
By their numbers in this assay, from the lowest: compounds 3 and 2 (each within the scatter of the next); then compounds 4 and 1 (each within the scatter of the next).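

Within the data shown here, compound 4 supplies the only single-place comparison in this set: in this assay, going from (tert-butyl)sulfanyl to isopropylsulfanyl, with hydrogen in place of methyl on a saturated chain carbon bound to two saturated chain carbons and a sulfur, gives a 1.3-fold lower number from compound 1 to compound 4 (0.10 log units; within the scatter) and so no shift that can be told from repeat measurement. Among these compounds, at this place, then, the removal of one methyl leaves the number unchanged within the scatter, and neither compound 1 nor compound 4 can be ranked above the other, whereas the earlier compounds could not isolate this group from their other differences. Nothing available here bears on why the two compounds read alike.

As far as these compounds go, it remains open whether the same flat response would hold with a larger change at this place, such as a cyclohexyl, a benzyl, or a chain ending in an amine or a carboxylic acid. Also open, from the compounds shown here alone, is how much of the gap between compound 1 and compounds 2 and 3 belongs to the ethyl they carry, since those compounds differ from compound 1 in more than one place.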